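From a polyether chain to a prenyl ether

This account rests on a few compounds, and the source may have more. Where it says the series, first, only, none or still open, it means among the compounds named here.

Compound 1 `COCCOCCOc1cccc2ccc(N)nc12` carries a (2-methoxyethoxy)methyl group on a saturated chain carbon bound to an oxygen on an aromatic ring. In an assay on cells with melanin-concentrating hormone receptor 1 (Homo sapiens) as the target, read by radioligand binding (a lower number here means a stronger inhibitor, a higher number a weaker inhibitor), compound 1 gives > 2000 nM, which is a limit of the assay and not a number. Compound 1 thus sits at the limit of > 2000 nM in this assay, at which 1 of the 3 values shown sits.

The smaller ethers on the same core are measured. Compound 2 `CC(C)Oc1cccc2ccc(N)nc12` gives 437 nM in this assay, and compound 3 `CC(C)C(C)Oc1cccc2ccc(N)nc12` gives 199 nM. Within the data shown here, the one step between measured compounds, a 2.2-fold lower number from compound 2 to compound 3 (0.34 log units; beyond the scatter), shows that a larger saturated group at this position is tolerated and gives a modestly lower number.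

Compound 4 `CC(C)=CCOc1cccc2ccc(N)nc12` is not yet measured. It differs from compound 1 by 2-methylprop-1-en-1-yl in place of (2-methoxyethoxy)methyl on a saturated chain carbon bound to an oxygen on an aromatic ring. The change removes both hydrogen-bond acceptors of the chain and brings in a group of four carbons with one double bond, closer in size to the group of compound 3 than to the polyether of compound 1. Among the measured compounds shown here, no measured step covers a double bond in this chain, so the expectation rests on compound 2 with 437 nM and on compound 3 with 199 nM, values that compound 4 is expected to approach. Compound 4 is therefore expected at 300 nM, in a range from 100 nM to 1000 nM. This estimate means a step of an at least 6.6-fold lower number from compound 1 to compound 4 (0.82 log units; beyond the scatter).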

Compound 4, half-maximal inhibitory concentration: > 2000 nM
Compound 4 gave a limit, no number; the forecaster's own chance of this, stated with the estimate: 10%; at least 6.6-fold (0.82 log units) between middle value and limit.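

In this assay compound 4 gives > 2000 nM, which is a limit of the assay and not a number. The steps from the saturated ethers are both beyond the scatter, an at least 10-fold higher number from compound 3 to compound 4 (1.00 log units; beyond the scatter) and an at least 4.5-fold higher number from compound 2 to compound 4 (0.66 log units; beyond the scatter), so at this position 3-methylbut-2-en-1-yl on an oxygen on an aromatic ring does not follow 1,2-dimethylpropyl or isopropyl, and the change in this assay is not a simple matter of replacing the (2-methoxyethoxy)methyl group with a smaller one that lacks its hydrogen-bond acceptors. Compound 1 and compound 4, with very different chains, now end up at the same limit of the assay: the limit of > 2000 nM in this assay, at which 2 of the 4 values shown sit.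

Both values for the pair of compound 1 and compound 4 are limits, so the step between them cannot be read and neither chain can be placed ahead of the other. The compounds shown also leave open whether the double bond itself or the unbranched attachment to the oxygen accounts for the loss, which a saturated 3-methylbutyl group on the same oxygen would separate.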